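The compounds below may be only part of what the source reports. "The series", "measured", "known", "first", "only" and "open" are said of these compounds alone.

In an assay for binding affinity to leukotriene B4 receptor 1 (Homo sapiens) (a higher number here means a weaker inhibitor, a lower number a stronger inhibitor), compound 1 (`COc1ccc(CCCCCCCCOc2ccc(C[S+]([O-])c3ccccc3)nc2/C=C/C(=O)O)cc1`) gives 37 nM. Among the compounds with values here, the only other measured compound, compound 2 (`CCCCCCCCCCCCOc1ccc(C[S+]([O-])c2ccccc2C(=O)O)nc1/C=C/C(=O)O`), gives 478 nM in this assay. Compound 1 therefore holds the lower of the two numbers, and compound 2 sits beyond the scatter from it; the two structures differ in more than one place, so their values can be set side by side but no single change can be read from them.

Compound 3 (`COc1ccc(CCCCCCCCOc2ccc(C[S+]([O-])c3cccc(OC)c3)nc2/C=C/C(=O)O)cc1`) has not yet been measured in this assay. It departs from compound 1 by methoxy in place of hydrogen on an aromatic carbon. Within the data shown here, no pair of measured compounds differs in exactly this way, so no measured step in this assay shows what such a change does. On the evidence of compound 1 alone, with its 37 nM as the only anchor, the change is expected to move the number little. The expected step is a 1.1-fold higher number from compound 1 to compound 3 (0.03 log units; within the scatter), small enough to stay within the scatter in either direction. Compound 3 is estimated at 40 nM, within a range from 12 nM to 130 nM.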

Compound 3, inhibition constant: 232 nM
Compound 3: middle estimate off by 5.8-fold (0.76 log units), on the low side; measured number above the stated range.
By their numbers in this assay, from the lowest: compound 1; then compound 3; then compound 2.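

Methoxy in place of hydrogen on an aromatic carbon, on the six-membered aromatic ring of carbon only and meta to a large group, gives a 6.3-fold higher number from compound 1 to compound 3 (0.80 log units; beyond the scatter) in this assay and is the first single change that can be read in this series. The step is modest but lies beyond the scatter, so phenyl to 3-methoxyphenyl is not a neutral exchange at this place on the core of compound 1, and the higher number means a weaker inhibitor. The comparison of compound 1 with compound 2 could not show this, as those two differ in more than one place, and nothing available here accounts for the size or direction of the step.

The compounds shown leave open whether a methyl, a hydroxyl or a fluorine at the same place would raise the number as methoxy does, or whether a carboxylic acid or an amine there would behave differently. They also leave open whether methoxy has the same effect elsewhere on this ring, or with the dodecyloxy chain of compound 2 in place of the chain of compound 1.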